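This account rests on a few compounds, and the source may have more. Where it says the series, first, only, none or still open, it means among the compounds named here.

For the measured compounds named here, compound 2 `COc1cccc(CN(C)C(=O)c2nn(-c3ccc(F)cc3)c(OC[C@@H](O)C[C@@H](O)CC(=O)O)c2C(C)C)c1` carries a (3-methoxybenzyl)(methyl)amino group on the carbonyl carbon of the shared core, and in an assay on microsomes from liver for inhibition of 3-hydroxy-3-methylglutaryl-coenzyme A reductase (Rattus norvegicus) (a lower number here means a stronger inhibitor, a higher number a weaker inhibitor), compound 2 gives 21 nM, the higher of the two numbers measured so far. Going by the values given here, its only neighbour, compound 1 `Cc1cccc(CNC(=O)c2nn(-c3ccc(F)cc3)c(OC[C@@H](O)C[C@@H](O)CC(=O)O)c2C(C)C)c1`, gives 4.9 nM in this assay. Among the compounds with values here, the single measured step, a 4.3-fold higher number from compound 1 to compound 2 (0.63 log units; beyond the scatter), altered the whole amide substituent at once rather than one part of it. Compound 3 `CC(C)c1c(C(=O)N(C)[C@H](C)c2ccccc2)nn(-c2ccc(F)cc2)c1OC[C@@H](O)C[C@@H](O)CC(=O)O` differs from compound 2 by 1-phenylethyl in place of 3-methoxybenzyl on an amide-type nitrogen, so the methyl on that nitrogen is retained. Within the data shown here, no measured step changes only this part of the molecule; the step from compound 1 to compound 2 bears on it only loosely, and its modest size suggests a change of comparable or smaller size, in either direction, in this assay. Compound 3 is therefore expected to give 18 nM in this assay, within 6 nM to 55 nM. The expected step is a 1.2-fold lower number from compound 2 to compound 3 (0.07 log units; within the scatter), close to the scatter.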

Compound 3, half-maximal inhibitory concentration: 21 nM
For compound 3 the middle estimate is 1.2-fold (0.07 log units) below the measured one, and the stated range covers the measured number.
By their numbers in this assay, from the lowest: compound 1; then compounds 2 and 3 (each within the scatter of the next).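

With the methyl on the amide-type nitrogen retained, replacing 3-methoxybenzyl with 1-phenylethyl gives no change at the digits printed from compound 2 to compound 3 (within the scatter) in this assay, so this exchange of one aromatic group for another, with the methoxy oxygen lost and a defined stereocentre gained, leaves the number in place. Going the other way, a 4.3-fold higher number from compound 1 to compound 3 (0.63 log units; beyond the scatter) is a shift beyond the scatter, and it matches in size the step already seen for compound 2, though each of these steps replaces the whole amide substituent at once. No measurement given here accounts for either result.

On these data alone, what remains open is how much of the shift from compound 1 belongs to the methyl on the nitrogen and how much to the group beside it in the name. As far as these compounds go, it is also open how an ethyl on that nitrogen, or an amine or carboxylic acid on the benzyl ring, would read in this assay here.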